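The source may hold more compounds than are shown below. What is called first, only, known or untested is meant among the compounds shown, and "the series" means these compounds.

Measured so far in an assay on HEK293 cells for inhibition of kynurenine 3-monooxygenase (Homo sapiens), read by LC-MS, with a stated time of 20 h; a higher number here means a weaker inhibitor, a lower number a stronger inhibitor:
- compound 1 `O=C(O)CCn1c(=O)oc2cc(OCc3ccccn3)c(Cl)cc21`: compound 1 gives 5010 nM
- compound 2 `CCc1cc2oc(=O)n(CCC(=O)O)c2cc1Cl`: compound 2 gives 316 nM
- compound 3 `Cc1ccc([C@@H](C)Oc2cc3onc(CCC(=O)O)c3cc2Cl)nn1`: compound 3 gives 3.16 nM

Compound 2 stands second highest of the three numbers; its nearest neighbour is compound 1, whose number is higher, and compound 3 lies furthest below it. For the measured compounds named here, the one measured step that bears directly on the ring position in question is a 16-fold lower number from compound 1 to compound 2 (1.20 log units; beyond the scatter): ethyl in place of (pyridin-2-yl)methoxy on an aromatic carbon.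

Compound 4 `C[C@@H](Oc1cc2oc(=O)n(CCC(=O)O)c2cc1Cl)c1ncco1` has not been measured. From compound 2 it differs as follows: a group of 8 heavy atoms (5 carbon, 1 nitrogen, 2 oxygen; one five-membered aromatic ring with 2 hetero atoms) in place of a group of 2 heavy atoms (2 carbon; no ring), on an aromatic carbon.

This change runs the step from compound 1 to compound 2 roughly in reverse, returning an ether bearing a heteroaromatic ring at that aromatic carbon, which on that step alone argues for a higher number. Against it, compound 3 carries a methyl-branched ether with a six-membered heteroaromatic ring at the matching position of a different core and gives 3.16 nM, the lowest number of the set; no step to compound 3 is available, since the core also differs. The expectation is therefore a modest step to a lower number, a 2.1-fold lower number from compound 2 to compound 4 (0.32 log units; beyond the scatter), with wide uncertainty. Compound 4 is estimated at 150 nM, within the range 20 nM to 1500 nM.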

Compound 4, half-maximal inhibitory concentration: 7940 nM
Compound 4: middle estimate off by 53-fold (1.72 log units), on the low side; measured number outside the range, above it.
By their numbers in this assay, from the lowest: compound 3; then compound 2; then compounds 1 and 4 (each within the scatter of the next).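

On the shared core, the ethyl group at this aromatic carbon is clearly preferred in this assay over the ether tested here: the change gives a 25-fold higher number from compound 2 to compound 4 (1.40 log units; beyond the scatter) and so shows, independently of compound 1, that ethyl outperforms a large ether-linked heteroaromatic group at this carbon. The part of the substituent beyond the oxygen has shown little sensitivity so far, since the five-membered aromatic ring with 2 hetero atoms and its methyl branch in place of the (pyridin-2-yl)methyl group give a 1.6-fold higher number from compound 1 to compound 4 (0.20 log units; within the scatter) and the two ethers cannot be told apart. This reading applies only to the shared core, compound 3 falling outside it, and no measurement at hand bears on the reason for the result.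

Small groups at this carbon, such as methoxy, an amine or a propyl chain, would show whether the oxygen link itself or the size of the whole group tracks with the higher numbers. For the compounds shown here, the effect of the defined stereocentre also stays open, as the methyl branch and the ring change together in the only comparison of the two ethers, and the opposite stereoisomer of compound 4 and an unbranched methylene analogue would separate them.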